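Swapping the alkyl group on the shared core

This account rests on a few compounds, and the source may have more. Where it says the series, first, only, none or still open, it means among the compounds named here.

Measured compounds:
compound 1, `O=C(Nc1ccc(F)cc1)OCC1(C(F)(F)F)OC(=O)Nc2ccc(Cl)cc21`, 142 nM
compound 2, `CCC1(COC(=O)Nc2ccc(F)cc2)OC(=O)Nc2ccc(Cl)cc21`, 2260 nM
compound 3, `CC(C)C1(COC(=O)Nc2ccc(F)cc2)OC(=O)Nc2ccc(Cl)cc21`, 5030 nM

All three were tested in an assay for inhibition of very long chain fatty acid elongase 6 (Homo sapiens); on this read-out lower numbers stand for stronger inhibition and higher numbers for weaker inhibition. Compound 3 gives the highest number of the three, weaker than compound 2 by a 2.2-fold higher number from compound 2 to compound 3 (0.35 log units; beyond the scatter) and weaker than compound 1 by a 35-fold higher number from compound 1 to compound 3 (1.55 log units; beyond the scatter).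

Compound 4, `O=C(Nc1ccc(F)cc1)OCC1(C2CC2)OC(=O)Nc2ccc(Cl)cc21`, has not been measured. It differs from compound 3 in one place: cyclopropyl in place of isopropyl on a saturated ring carbon. Among the measured compounds shown here, no measured step covers this exact exchange. For the measured compounds named here, the steps that bear on it are those at the same position: the step of a 16-fold higher number from compound 1 to compound 2 (1.20 log units; beyond the scatter) and the step of a 35-fold higher number from compound 1 to compound 3 (1.55 log units; beyond the scatter) show that plain alkyl groups in place of trifluoromethyl give far weaker inhibition, and the step of a 2.2-fold higher number from compound 2 to compound 3 (0.35 log units; beyond the scatter) shows that a larger alkyl group weakens it a little further. Cyclopropyl is an alkyl group of the same atom count as isopropyl, so compound 4 is expected to stay near compound 3, with at most a modest step of a 1.4-fold lower number from compound 3 to compound 4 (0.16 log units; within the scatter) in this assay.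

The estimate for compound 4 is 3500 nM, within a range of 1500 nM to 8000 nM.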

Compound 4, half-maximal inhibitory concentration: 1410 nM
Compound 4: the middle estimate sits 2.5-fold (0.39 log units) above what was measured; the whole stated range lies above it.
By their numbers in this assay, from the lowest: compound 1; then compounds 4 and 2 (each within the scatter of the next); then compound 3.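

Cyclopropyl in place of isopropyl gives a 3.6-fold lower number from compound 3 to compound 4 (0.55 log units; beyond the scatter) in this assay even though both groups hold 3 carbons, so closing the chain into a ring matters at this saturated ring carbon. The step of a 1.6-fold lower number from compound 2 to compound 4 (0.20 log units; within the scatter) means compound 4 cannot be told apart from compound 2, so the earlier trend of weaker inhibition with a bigger alkyl group does not extend to cyclopropyl. Trifluoromethyl still gives the lowest number here, since a 9.9-fold higher number from compound 1 to compound 4 (1.00 log units; beyond the scatter) remains when cyclopropyl takes its place.

Nothing available explains why the ring form differs from the open chain or why trifluoromethyl stands apart. From the compounds shown here alone, whether a cyclobutyl or a difluoromethyl group on this ring carbon would come closer to compound 1 stays open.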